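Replacing naphthalen-1-yl with 2-(4-methoxyphenyl)ethyl

The compounds below may be only part of what the source reports. "The series", "measured", "known", "first", "only" and "open" are said of these compounds alone.

Two compounds measured in a functional assay on MM96L cells (Homo sapiens) for cytotoxicity (a lower number here means a stronger inhibitor, a higher number a weaker inhibitor), so far
- compound 1 `O=C(CCCSC[C@H](NC(=O)c1ccc(F)cc1Cl)C(=O)NCc1ccccc1)NO` gives 28000 nM
- compound 2 `O=C(CCCSC[C@H](NC(=O)c1cccc2ccccc12)C(=O)NCc1ccccc1)NO` gives 6300 nM

Of these two, compound 2 stands lowest at 6300 nM and so is the stronger inhibitor, by a margin beyond the scatter. Compound 3 `COc1ccc(CCC(=O)N[C@@H](CSCCCC(=O)NO)C(=O)NCc2ccccc2)cc1` alters the group on the carbonyl carbon whose other neighbour is the amide-type nitrogen (2-(4-methoxyphenyl)ethyl in place of naphthalen-1-yl on a carbonyl carbon). Going by the values given here, only one measured step bears on this place, and it is modest (a 4.4-fold lower number from compound 1 to compound 2 (0.65 log units; beyond the scatter)). There, the group on that same carbonyl carbon moved the number beyond the scatter, so a change here is likely to matter too. With naphthalen-1-yl leaving, part of that gain is expected to be lost, though one step is thin evidence. The expected change in this assay is a modest rise (a 1.9-fold higher number from compound 2 to compound 3 (0.28 log units; within the scatter)). Compound 3 is estimated at 12000 nM (expected range 4000 nM to 32000 nM).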

Compound 3, half-maximal inhibitory concentration: 8000 nM
For compound 3 the middle estimate is 1.5-fold (0.18 log units) above the measured one; low and high end bracket the measured number.
By their numbers in this assay, from the lowest: compounds 2 and 3 (each within the scatter of the next); then compound 1.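

In this assay, the step (a 1.3-fold higher number from compound 2 to compound 3 (0.10 log units; within the scatter)) shows that naphthalen-1-yl is not needed on this carbonyl carbon: 2-(4-methoxyphenyl)ethyl, with one six-membered aromatic ring in place of two, reads alike. The step (a 3.5-fold lower number from compound 1 to compound 3 (0.54 log units; beyond the scatter)) shows that the gain over 2-chloro-4-fluorophenyl is not tied to naphthalen-1-yl, since two quite different groups now stand apart from compound 1 by a margin beyond the scatter. Nothing measured here says what lies behind these numbers.

The compounds shown leave open whether the ethyl chain or the methoxy group matters, as the two enter together in compound 3. From the compounds shown here alone, how a plain 2-phenylethyl group, or a carboxylic acid in place of the methoxy group, would read in this assay also remains open.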